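The source may hold more compounds than are shown below. What is called first, only, known or untested is meant among the compounds shown, and "the series" means these compounds.

Measured compounds:
- compound 1, `COc1ccc(C(=O)c2ccccc2)c(Oc2ccnc(Nc3ccc(C#N)cc3)n2)c1`: 760 nM
- compound 2, `N#Cc1ccc(Nc2nccc(Oc3ccc(C(=O)c4ccc(O)cc4)cc3)n2)cc1`: 19400 nM
- compound 3, `Cc1cc(Oc2ccc(C(=O)c3ccc(O)cc3)cc2)nc(Nc2ccc(C#N)cc2)n1`: 32000 nM

All three values come from an ADME assay on MT4 cells (Homo sapiens) for cytotoxicity, read by MTT assay, with a stated time of 5 days; a higher number here means that more compound is tolerated, a lower number that less compound is tolerated. Compound 1 gives the lowest number of the three, and its gaps to compound 2 and to compound 3 both lie beyond the scatter. How the core of compound 1 differs from the core of compound 2 is not broken down here.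

Compound 2 and compound 3 differ in one place: methyl in place of hydrogen on an aromatic carbon. In this assay the step is a 1.6-fold higher number from compound 2 to compound 3 (0.22 log units; within the scatter).

The compound now in question is compound 4, `COc1ccc(C(=O)c2ccccc2)c(Oc2nc(Nc3ccc(C#N)cc3)ncc2C)c1`. It differs from compound 1 by methyl in place of hydrogen on an aromatic carbon. This is the same kind of change as from compound 2 to compound 3, not the same change: in compound 3 the methyl sits next to the ring nitrogen, meta to the (4-cyanophenyl)amino group, meta to a large group and opposite the ring nitrogen, whereas in compound 4 it sits ortho to a large group, two atoms from the ring nitrogen and para to the (4-cyanophenyl)amino group.

For the measured compounds named here, the one earlier instance of this kind of change is the only guide, and it rests on that because a 1.6-fold higher number from compound 2 to compound 3 (0.22 log units; within the scatter) stayed within the scatter. A step of similar size is therefore expected, a 1.3-fold higher number from compound 1 to compound 4 (0.12 log units; within the scatter), set beside the earlier one. In this assay compound 4 is expected to give 1000 nM, estimated to fall between 400 nM and 2500 nM.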

Compound 4, half-maximal cytotoxic concentration: 7420 nM
Beside the measured number, compound 4's estimate is 7.4-fold (0.87 log units) below it, outside the stated range (above it).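

In this assay, methyl in place of hydrogen on an aromatic carbon gives a clear step on this core, a 9.8-fold higher number from compound 1 to compound 4 (0.99 log units; beyond the scatter), so the change that made no readable difference on the other core does make one here. The size of the step therefore did not carry from one core to the other, and the earlier pair would have been a poor guide to this one: the same change on two cores in this assay, a 1.6-fold higher number (0.22 log units; within the scatter) from compound 2 to compound 3 and a 9.8-fold higher number (0.99 log units; beyond the scatter) from compound 1 to compound 4, 5.9-fold (0.77 log units) apart, beyond the scatter of two such steps This does not show that the core alone sets the size of the step, since the methyl also stands at a different place on the ring in the two pairs, and two pairs cannot separate the core from the place or support a general rule for the series.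

Still open, from the compounds shown here alone, is whether the methyl placed as in compound 4 on the core of compound 2, or placed as in compound 3 on the core of compound 1, would give a step of the size seen on the same core or on the other one. Also open, going by these compounds, is whether the step on the core of compound 1 is specific to methyl or would also appear with an ethyl group or a chlorine atom at the same place.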